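This account rests on a few compounds, and the source may have more. Where it says the series, first, only, none or still open, it means among the compounds named here.

Within the data shown here, compound 2 (`Cc1ncncc1-c1nc2cc(F)c(F)cc2n1C1CC1`) is the one compound here with a measured number: in an ADME assay on cells for inhibition of cytochrome P450 11B1, mitochondrial (Homo sapiens), read by HPLC, with a stated time of 60 min (a higher number here means a weaker inhibitor, a lower number a stronger inhibitor), compound 2 gives 4160 nM. Compound 1 (`Fc1ccc2nc(-c3cccnn3)n(C3CC3)c2c1`) sits at the limit of > 10000 nM in this assay, at which 1 of the 2 values shown sits, so its value of > 10000 nM is a limit and not a number. Compound 3 (`Fc1cc2nc(-c3cncnc3C(F)(F)F)n(C3CC3)c2cc1F`) is not yet measured; it differs from compound 2 by trifluoromethyl in place of methyl on an aromatic carbon. Among the measured compounds shown here, no measured pair shows this change, so the step is expected to be small, at or barely beyond the scatter, leaning toward weaker inhibition. Compound 3 is expected at 5500 nM, within 2000 nM to 12000 nM. The expected step is a 1.3-fold higher number from compound 2 to compound 3 (0.12 log units; within the scatter).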

Compound 3, half-maximal inhibitory concentration: 4770 nM
Estimate against measurement, compound 3: 1.2-fold (0.06 log units) above; low and high end bracket the measured number.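

The swap of methyl for trifluoromethyl on this aromatic carbon now has a measured size: a 1.1-fold higher number from compound 2 to compound 3 (0.06 log units; within the scatter). In this assay, the two groups cannot be told apart at this position, at least on this core. Compound 3 also gives a real number rather than a limit, unlike one compound here: the limit of > 10000 nM in this assay, at which 1 of the 3 values shown sits.

From the compounds shown here alone, it remains open whether a different kind of group on this carbon, such as an amine or a carboxylic acid, would shift the number beyond the scatter. Compound 1 differs from the others in more than one place, so it isolates no single change.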